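Homologated ester warhead on the acetylated pentapeptide

The source may hold more compounds than are shown below. What is called first, only, known or untested is meant among the compounds shown, and "the series" means these compounds.

For the measured compounds named here, compound 1 `CC(=O)N[C@@H](CO)C(=O)N[C@@H](C)C(=O)N[C@H](C(=O)N[C@@H](CC(C)C)C(=O)N[C@H](C=O)CCC(=O)N(C)C)C(C)C` carries a formyl group and, in an assay for inhibition of chymotrypsin-like protease CTRL-1 variant R188I (Homo sapiens), read by HPLC, with stated times of 20 min and 60 min (a higher number here means a weaker inhibitor, a lower number a stronger inhibitor), gives 37000 nM, the lower of the two numbers so far. Compound 2 `CCOC(=O)/C=C/[C@H](CCC(=O)N(C)C)NC(=O)[C@H](CC(C)C)NC(=O)[C@@H](NC(=O)[C@H](C)NC(=O)[C@H](CO)NC(C)=O)C(C)C` gives 330000 nM in this assay, and the step of an 8.9-fold higher number from compound 1 to compound 2 (0.95 log units; beyond the scatter) shows that exchanging the formyl for the ethenyl ester costs potency. Compound 3 `CCOC(=O)/C=C/C[C@H](CCC(=O)N(C)C)NC(=O)[C@H](CC(C)C)NC(=O)[C@@H](NC(=O)[C@H](C)NC(=O)[C@H](CO)NC(C)=O)C(C)C` goes one carbon further: 3-(ethoxycarbonyl)prop-2-en-1-yl in place of formyl on a saturated chain carbon bound to an amide-type nitrogen and a saturated chain carbon. Going by the values given here, only the step from compound 1 to compound 2 bears on this, and it was a loss, so compound 3 is expected to lose as well, roughly an 11-fold higher number from compound 1 to compound 3 (1.03 log units; beyond the scatter) in this assay. Compound 3 is estimated at 400000 nM, within 100000 nM to 1500000 nM.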

Compound 3, half-maximal inhibitory concentration: "not active" (no number reported)
For compound 3 the study gives words and no number; the estimate stays without a comparison.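

For the compounds shown here, compound 3 is reported only as "not active", without a number, so no step from compound 1 or compound 2 can be read. The compounds shown leave open how much weaker compound 3 is than compound 2, if at all. No evidence bears on this result.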